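The source may report more compounds than this note shows. Statements on the series, on what has been measured and on what is new or still open speak of the compounds shown alone.

Notes on the series begin with compound 1 `COc1ccc(-c2nc(C)nn2-c2cccc(C(=O)NCCCc3ccc(Br)cc3)c2)cc1` and compound 2 `COc1ccc(-c2nc(C)nn2-c2cccc(C(=O)NCCCc3ccc(Cl)cc3)c2)cc1`, both read in a functional assay on PANC-1 cells (Homo sapiens), read by microscopy, crystal violet staining and transwell migration, with a stated time of 18 h, in the presence of a further agent that is not named here; a higher number here means a weaker inhibitor, a lower number a stronger inhibitor. In this assay compound 1 gives > 20000 nM, which is a limit and not a number. In this assay compound 2 gives > 20000 nM, which is also a limit and gives compound 2 no numeric place in the series. The two compounds stand together: the limit of > 20000 nM in this assay, at which 2 of the 2 values shown sit.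

Compound 3 `COc1ccc(-c2nc(C)nn2-c2cccc(C(=O)NCCCCc3ccc(Br)cc3)c2)cc1` is the next to be read. Its difference from compound 2 is 4-bromobenzyl in place of 4-chlorophenyl on a saturated chain carbon, three bonds along the chain from an amide-type nitrogen. In words, this is 4-bromobenzyl in place of 4-chlorophenyl on a saturated chain carbon, three bonds along the chain from an amide-type nitrogen.

Among the compounds with values here, only one measured step bears on this change, a step that the two limits leave unreadable from compound 1 to compound 2, and it offers neither a size nor a direction. No step beyond the scatter is therefore expected in this assay, and no direction is favoured. The expected change is a number no higher from compound 2 to compound 3 (the limit leaves the size open). A further limit is the likeliest report. For compound 3 the estimated value is 20000 nM, with an expected range from 5000 nM to 40000 nM.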

Compound 3, half-maximal inhibitory concentration: 3020 nM
Compound 3: the middle estimate sits 6.6-fold (0.82 log units) above what was measured; measured number below the stated range.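

Within the data shown here, at the saturated chain carbon, three bonds along the chain from an amide-type nitrogen, 4-bromobenzyl in place of 4-bromophenyl gives in this assay an at least 6.6-fold lower number from compound 1 to compound 3 (0.82 log units; beyond the scatter) and the first readable step, with the bromo kept on the aromatic ring. The same longer chain set against the chloro compound, where the halogen changes as well, gives an at least 6.6-fold lower number from compound 2 to compound 3 (0.82 log units; beyond the scatter) and so is a less clean reading of the chain alone. From the compounds shown here alone, both steps start from a limit, so their true sizes stay open, and compound 3 alone carries a number while the two shorter-chain compounds remain at the limit: the limit of > 20000 nM in this assay, at which 2 of the 3 values shown sit.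

The step between the two shorter-chain compounds cannot be read, so the exchange of bromo for chloro has no size yet, and a 4-chlorobenzyl group at this place on the chain of compound 3 would be needed to give it one. Also open, going by these compounds, is whether a still longer chain continues the drop in the number or reverses it, and whether an amine or a carboxylic acid in place of the halogen is tolerated on this chain.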